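A few compounds are considered here, and "the series" means these few. Any claim that something is new, unique, unknown or untested is made for them only; others in the source may bear on it.

Measured compounds in a functional assay on SW1573 cells (Homo sapiens) for cytotoxicity, read by sulforhodamine B assay, with a stated time of 72 h; on this read-out lower numbers stand for stronger inhibition and higher numbers for weaker inhibition:
Compound 1 `CCCC(=O)Nc1ccn([C@@H]2CO[C@H](CO)O2)c(=O)n1` gives 8070 nM.
Compound 2 `CCCCCCCCCCCCCCCCCCCC(=O)Nc1ccn([C@@H]2CO[C@H](CO)O2)c(=O)n1` gives 150 nM.
Compound 3 `O=C(Nc1ccn([C@@H]2CO[C@H](CO)O2)c(=O)n1)c1ccc(Br)cc1` gives 8870 nM.

Compound 1 holds the second highest of the three numbers. Its nearest neighbour is compound 3, and compound 2 stands furthest away with a far lower number, beyond the scatter.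

The unmeasured compound 4 `O=C(Nc1ccn([C@@H]2CO[C@H](CO)O2)c(=O)n1)c1ccc(Cl)cc1Cl` differs from compound 1 by one change: 2,4-dichlorophenyl in place of propyl on a carbonyl carbon

Among the compounds with values here, one measured step bears on this. From compound 1 to compound 3 the same carbonyl carbon carries 4-bromophenyl in place of propyl, and the result was a 1.1-fold higher number from compound 1 to compound 3 (0.04 log units; within the scatter). That step exchanges propyl for a halogenated aromatic ring and left the number where it was. The step to compound 4 exchanges propyl for another halogenated aromatic ring, 2,4-dichlorophenyl, so the expectation is the same: no step beyond the scatter in this assay. The large drop seen for compound 2 comes with a long unbranched carbon chain, not an aromatic ring, and is not taken as relevant here.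

For compound 4 the estimate in this assay is 7500 nM, with a range from 2500 nM to 22000 nM. This estimate means a step of a 1.1-fold lower number from compound 1 to compound 4 (0.03 log units; within the scatter), expected to stay within the scatter.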

Compound 4, half-maximal inhibitory concentration: 14300 nM
Compound 4: middle estimate off by 1.9-fold (0.28 log units), on the low side; measured number inside the range.
By their numbers in this assay, from the lowest: compound 2; then compounds 1, 3 and 4 (each within the scatter of the next).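

In this assay the carbonyl carbon on the amide-type nitrogen now has a second halogenated aromatic group on record, and the change to 2,4-dichlorophenyl gives a 1.8-fold higher number from compound 1 to compound 4 (0.25 log units; within the scatter) and so does not separate this group from propyl. The exchange between the two aromatic groups gives a 1.6-fold higher number from compound 3 to compound 4 (0.21 log units; within the scatter) and also stays unresolved, so 4-bromophenyl and 2,4-dichlorophenyl cannot be told apart here, despite the different halogens and the second ring substituent, and compounds 1, 3 and 4 form one band with compound 2 alone standing apart. No measurement is available that explains why these groups read alike.

The compounds shown leave open how the number moves between propyl and the long unbranched chain of compound 2, which an octyl or dodecyl chain on the same carbonyl carbon would help to settle. They also leave open whether an aromatic ring carrying an amine or a carboxylic acid, or a phenyl ring with no halogen, would stay in the same band as compounds 1, 3 and 4.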